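Inverting two ring stereocentres in a cytotoxic compound

This account rests on a few compounds, and the source may have more. Where it says the series, first, only, none or still open, it means among the compounds named here.

Measured in a functional assay on CCRF-CEM cells (Homo sapiens) for cytotoxicity; a lower number here means a stronger inhibitor, a higher number a weaker inhibitor:
compound 1 `C=C1C(=O)O[C@H]2C[C@H](C)C3=C(C[C@H]12)[C@]1(C)C[C@@H]3C[C@@]12C(=O)O[C@@H]1C[C@@]3(C)[C@@H](O)C[C@@H](O)C(=C)[C@@H]3C[C@@H]12`: 140 nM
compound 2 `C=C1C(=O)O[C@H]2C[C@H](C)[C@@]34C[C@@H](C[C@@]35C(=O)O[C@@H]3C[C@@]6(C)[C@@H](O)C[C@@H](O)C(=C)[C@@H]6C[C@@H]35)C(C)=C4C[C@H]12`: 140 nM

Compound 1 stands level with compound 2, as the two values lie within the usual scatter. The next compound, compound 3 `C=C1C(=O)O[C@H]2C[C@H](C)C3=C(C[C@H]12)[C@@]1(C)C[C@H]3C[C@@]12C(=O)O[C@@H]1C[C@@]3(C)[C@@H](O)C[C@@H](O)C(=C)[C@@H]3C[C@@H]12`, is a stereoisomer of compound 1: the two compounds have the same atoms and bonds and differ only in configuration as drawn: 2 of 12 stereo elements differ; a stereocentre at a saturated ring carbon is drawn S in compound 1 and R in compound 3; a stereocentre at a saturated ring carbon is drawn R in compound 1 and S in compound 3. Within the data shown here, no measured pair here shows what such a change does in this assay, so any expectation is loose. A modest weakening seems more likely than a gain, and no real change remains possible. The expected size of this move is a 1.8-fold higher number from compound 1 to compound 3 (0.25 log units; within the scatter). The estimated value for compound 3 is 250 nM, with an expected range from 80 nM to 900 nM.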

Compound 3, half-maximal inhibitory concentration: 140 nM
Beside the measured number, compound 3's estimate is 1.8-fold (0.25 log units) above it, within the range that was stated.
By their numbers in this assay, from the lowest: compounds 1, 2 and 3 (each within the scatter of the next).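

In this assay, inverting the two ring stereocentres gives no change at the digits printed from compound 1 to compound 3 (within the scatter). Among these compounds, no earlier pair tested such a change, and this one shows that the configuration drawn at these two saturated ring carbons can be switched together with no visible effect on the read-out. The comparison isolates configuration alone: the fact that compounds 1 and 3 differ only in the configuration as drawn

Going by these compounds, the effect of inverting either stereocentre on its own remains open. So does what an added amine or a longer chain on the shared core would do to the read-out.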